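The compounds below may be only part of what the source reports. "The series", "measured", "known", "first", "only" and "open" are said of these compounds alone.

Measured compounds:
compound 1 `CCS(=O)(=O)Nc1ccc(NC(=O)c2ccc(Cl)cc2)cc1OC`: 60100 nM
compound 2 `CCS(=O)(=O)Nc1ccc(NC(=O)c2ccc(Cl)cc2)cc1Cl`: > 250000 nM
compound 3 `O=C(Nc1ccc(NS(=O)(=O)C(F)(F)F)c(Cl)c1)c1ccc(Cl)cc1`: 47200 nM

In an ADME assay on RAW264.7 cells (Mus musculus) for cytotoxicity, read by MTT assay, with a stated time of 48 h (on this read-out higher numbers stand for weaker inhibition and lower numbers for stronger inhibition), compound 2 gives > 250000 nM, which is a limit of the assay and not a number. Compound 2 therefore sits at the limit of > 250000 nM in this assay, at which 1 of the 3 values shown sits. Compound 1 gives 60100 nM and compound 3 gives 47200 nM, both measured numbers. Compound 4 `CCS(=O)(=O)Nc1ccc(NC(=O)c2ccc(Cl)cc2)cc1F` differs from compound 2 by fluoro in place of chloro on an aromatic carbon. Among the compounds with values here, no measured step exchanges these two halogens; the closest is an at least 4.1-fold higher number from compound 1 to compound 2 (0.61 log units; beyond the scatter), at the same aromatic carbon, and the other measured step, an at least 5.2-fold lower number from compound 2 to compound 3 (0.72 log units; beyond the scatter), alters the sulfonyl substituent instead. Both steps were of modest size, so a modest step, most likely toward a lower number, is expected here. Compound 4 is expected to give 150000 nM, within 50000 nM to 300000 nM, an expected step of an at least 1.6-fold lower number from compound 2 to compound 4 (0.22 log units; that floor lies within the scatter).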

Compound 4, half-maximal inhibitory concentration: 152000 nM
Compound 4: the middle estimate sits 1.0-fold (0.01 log units) below what was measured, and the stated range covers the measured number.
By their numbers in this assay, from the lowest: compounds 3 and 1 (each within the scatter of the next); then compound 4. At a limit, above all of these: compound 2.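

In this assay, fluoro on this aromatic carbon, ortho to the (ethylsulfonyl)amino group, gives a halogen compound a measured number, so the change from methoxy can now be sized: a 2.5-fold higher number from compound 1 to compound 4 (0.40 log units; beyond the scatter). The exchange of the two halogens reads as an at least 1.6-fold lower number from compound 2 to compound 4 (0.21 log units; that floor lies within the scatter), so it cannot be firmly said to change the number. Compound 2 stands at a limit and not at a number: the limit of > 250000 nM in this assay, at which 1 of the 4 values shown sits.

The compounds shown leave open how a bromo group or an amine on this carbon would read. They also leave open whether fluoro here would behave the same with trifluoromethyl in place of ethyl on the sulfonyl sulfur.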